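Extending the methoxy of compound 3 to isobutoxy

The compounds below may be only part of what the source reports. "The series", "measured", "known", "first", "only" and "open" are said of these compounds alone.

Of the compounds shown here, three of one series have been measured in a functional assay for agonist activity at Bile acid receptor (Homo sapiens), read by FRET; a higher number here means that more compound is needed for the effect, a lower number that less compound is needed. Compound 1 `CC(C)c1onc(-c2c(Cl)cccc2Cl)c1COc1ccc(-c2ccc3c(C(=O)O)nccc3c2)cc1` gives 380 nM. Compound 2 `CC(C)c1onc(-c2c(Cl)cccc2Cl)c1COc1ccc(-c2cc3ccc(C(=O)O)nc3cc2F)cc1` gives 240 nM in this assay. Compound 3 `COc1cc(C(=O)O)nc2ccc(-c3ccc(OCc4c(-c5c(Cl)cccc5Cl)noc4C(C)C)cc3)cc12` gives 58 nM, the lowest of the three; its gaps to compound 2 and to compound 1 are both beyond the scatter, so compound 3 stands as the most potent of the measured set.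

Compound 4 `CC(C)COc1cc(C(=O)O)nc2ccc(-c3ccc(OCc4c(-c5c(Cl)cccc5Cl)noc4C(C)C)cc3)cc12` has not been measured. It differs from compound 3 by isopropyl in place of hydrogen on a saturated chain carbon bound to an oxygen on an aromatic ring. For the measured compounds named here, no measured pair shows this change, so its effect cannot be read from the compounds at hand, and the direction is open. Going by the values given here, with no comparable pair, a step of modest size, possibly within the scatter, is expected in either direction. Compound 4 is estimated at 80 nM, with a range from 25 nM to 250 nM. The step in this assay is expected to be a 1.4-fold higher number from compound 3 to compound 4 (0.14 log units; within the scatter).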

Compound 4, half-maximal effective concentration: 78 nM
Compound 4: middle estimate off by 1.0-fold (0.01 log units), on the high side, within the range that was stated.
By their numbers in this assay, from the lowest: compounds 3 and 4 (each within the scatter of the next); then compounds 2 and 1 (each within the scatter of the next).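

Extending methoxy to isobutoxy gives, in this assay, a 1.3-fold higher number from compound 3 to compound 4 (0.13 log units; within the scatter), and this is the first step in the series between two compounds that differ in one place. It shows that isopropyl can enter on the saturated chain carbon bound to an oxygen on an aromatic ring while the number stays within the scatter of the methoxy parent, so this place accepts the larger isobutoxy group in this read-out. Nothing at hand explains why the added atoms leave the number within the scatter.

Still open, on these data alone, is whether this holds for a longer chain, such as n-hexyloxy, or for a chain ending in an amine. Also open, as far as these compounds go, is how a hydroxyl in place of the methoxy would read in this assay.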